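Swapping the Aryl Substituent in a Piperazine Urea Antagonist

The compounds below may be only part of what the source reports. "The series", "measured", "known", "first", "only" and "open" are said of these compounds alone.

Compound 1, `CC(C)c1ccc(NC(=O)N2CCN(c3ncccc3[N+](=O)[O-])CC2)cc1`: 245 nM in a functional assay on HEK293 cells for antagonist activity at transient receptor potential cation channel subfamily V member 1 (Rattus norvegicus); on this read-out lower numbers stand for stronger inhibition and higher numbers for weaker inhibition
Compound 2, `CC(C)c1ccc(NC(=O)N2CCN(c3ncccc3Cl)CC2)cc1`: 17.3 nM in this assay
Compound 3, `CC(C)c1ccc(NC(=O)N2CCN(c3ncccc3C(F)F)CC2)cc1`: 61.5 nM in this assay

The three measured compounds share one core and differ only at a single aromatic carbon. Compound 2 stands lowest of the three in this assay: the change from nitro to chloro gives a 14-fold lower number from compound 1 to compound 2 (1.15 log units; beyond the scatter), nitro to difluoromethyl gives a 4.0-fold lower number from compound 1 to compound 3 (0.60 log units; beyond the scatter), and chloro to difluoromethyl gives a 3.6-fold higher number from compound 2 to compound 3 (0.55 log units; beyond the scatter).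

Compound 4, `O=C(Nc1ccc(Cl)cc1)N1CCN(c2ncccc2Cl)CC1`, alters compound 2 at the opposite end of the molecule: chloro in place of isopropyl on an aromatic carbon. Among the measured compounds shown here, none of the measured steps concerns this position; all three vary the same other aromatic carbon, so they offer no direct guide to how this assay responds here. The direction and size of the step are therefore uncertain, and a modest weakening is expected, a 2.3-fold higher number from compound 2 to compound 4 (0.36 log units; beyond the scatter). Compound 4 is estimated at 40 nM, with a range from 10 nM to 160 nM.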

Compound 4, half-maximal inhibitory concentration: 2670 nM
Compound 4: middle estimate off by 67-fold (1.82 log units), on the low side; measured number outside the range, above it.
By their numbers in this assay, from the lowest: compound 2; then compound 3; then compound 1; then compound 4.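

In this assay, the aromatic carbon para to a large group proves far more sensitive than the carbon varied among compound 1, compound 2 and compound 3: chloro in place of isopropyl gives a 150-fold higher number from compound 2 to compound 4 (2.19 log units; beyond the scatter), well beyond the largest earlier step, a 14-fold lower number from compound 1 to compound 2 (1.15 log units; beyond the scatter). Among the compounds shown here, the isopropyl of compound 2 therefore matters greatly, and a chloro that gives the lowest number of the first three compounds at the other aromatic carbon gives the highest number of all four here. Nothing available accounts for the size of this step.

For the compounds shown here, with only this one change at the position, it remains open how much of the step reflects losing isopropyl and how much reflects gaining chloro. Going by these compounds, how an ethyl, a tert-butyl or a methoxy group would stand here also remains open.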